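Changing the aryl group on the nitrogen of compound 1

The source may report more compounds than this note shows. Statements on the series, on what has been measured and on what is new or still open speak of the compounds shown alone.

Compound 1 `CN(c1cccc2c1CN(c1nc(Nc3ccc(C(F)(F)F)cc3)ncc1C(F)(F)F)C2)S(C)(=O)=O` is measured in an assay on Sf9 cells for inhibition of tyrosine-protein kinase receptor UFO (Homo sapiens), read by luminescence and ADP-Glo; on this read-out lower numbers stand for stronger inhibition and higher numbers for weaker inhibition. The value reported for compound 1 is a limit of the assay, > 20000 nM. Compound 2 `Cc1ccc(Nc2ncc(C(F)(F)F)c(N3Cc4cccc(N(C)S(C)(=O)=O)c4C3)n2)c(Cl)c1` also sits at a limit, > 20000 nM. Compound 3 `CC(=O)N1CCN(c2ccc(Nc3ncc(C(F)(F)F)c(N4Cc5cccc(N(C)S(C)(=O)=O)c5C4)n3)cc2)CC1` lies at the other limit, < 0.5 nM. The step of an at least 40000-fold lower number from compound 1 to compound 3 (4.60 log units; beyond the scatter) is the only readable one; the step that the two limits leave unreadable from compound 1 to compound 2 concerns the same place as the change to compound 4 `CN(c1cccc2c1CN(c1nc(Nc3cc(Cl)cc(C(F)(F)F)c3)ncc1C(F)(F)F)C2)S(C)(=O)=O`, namely (3-chloro-5-(trifluoromethyl)phenyl in place of 4-(trifluoromethyl)phenyl on a nitrogen on an aromatic ring). With compound 2 showing no gain from a change at that place, compound 4 is expected to stay near the weak end, a step of a number no higher from compound 1 to compound 4 (the limit leaves the size open) in this assay. The estimate for compound 4 is 20000 nM, ranging from 4000 nM to 60000 nM.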

Compound 4, half-maximal inhibitory concentration: > 30000 nM
Compound 4 ended at the assay's limit; the forecaster's own chance of this, stated with the estimate: 70%; at least 1.5-fold (0.17 log units) between middle value and limit.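

Compound 4, like compound 1 and compound 2, is reported only as a limit, so neither new step can be read. The compounds shown leave open how these three aryl groups on the nitrogen rank against one another.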